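Thiophene in Place of Furan on a Shared Core

This account rests on a few compounds, and the source may have more. Where it says the series, first, only, none or still open, it means among the compounds named here.

Compound 3 `CC1=C(C(=O)OC2CCCCC2)C(c2ccco2)NC(=O)N1` was tested in an assay on membranes from HEK293 cells for displacement of a labelled ligand from adenosine receptor A2b (Homo sapiens), read by scintillation counting, with a stated time of 30 min, tested at 1 uM (a higher number here means more inhibition at the concentration tested (going by the name of the read-out), a lower number less inhibition), where compound 3 gives 1%. Two related compounds set the context. Compound 1 `CCNC(=O)C1=C(C)NC(=O)NC1c1ccsc1` gives 1% in this assay, and compound 2 `CCN(CC)C(=O)C1=C(C)NC(=O)NC1c1ccsc1` gives 11%. Compound 3 is level with compound 1 at the digits shown, and together they are the lowest of the three numbers; compound 2 stands a little higher, but within the scatter. Among the measured compounds shown here, the only measured step between close neighbours is a number 10 percentage points higher from compound 1 to compound 2 (within the scatter), which alters an amide-type nitrogen and lies within the scatter.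

Compound 4 `CC1=C(C(=O)OC2CCCCC2)C(c2ccsc2)NC(=O)N1` is not yet measured. It differs from compound 3 in one place: thiophen-3-yl in place of furan-2-yl on a saturated ring carbon. For the measured compounds named here, no measured pair isolates this exchange of one aromatic ring for another; compounds 1 and 2 carry thiophen-3-yl but differ from compound 3 elsewhere too, so their values show only that this ring appears on compounds with low inhibition. Going by the values given here, with all three values low and the single measured step within the scatter, nothing beyond the scatter is expected here. Compound 4 is therefore expected to give 3%, between -8% and 14%. The expected change is a number 2 percentage points higher from compound 3 to compound 4 (within the scatter), which is expected to stay within the scatter.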

Compound 4, a percentage reported as inhibition, at one concentration (the size of the read-out at that concentration, not a potency): 4%
For compound 4 the middle estimate is 1 percentage points below the measured one; the range from low to high includes it.
By their numbers in this assay, from the lowest: compounds 1, 3, 4 and 2 (each within the scatter of the next).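

In this assay, the exchange of thiophen-3-yl in place of furan-2-yl on a saturated ring carbon now has a direct pair, and it gives a number 3 percentage points higher from compound 3 to compound 4 (within the scatter), so swapping these two five-membered aromatic rings, each with 5 heavy atoms, makes no difference here that can be told from the scatter. Compound 4 also allows the group on the carbonyl carbon to be read with the thiophen-3-yl ring held constant: cyclohexyloxy in place of diethylamino gives a number 7 percentage points lower from compound 2 to compound 4 (within the scatter), and cyclohexyloxy in place of ethylamino gives a number 3 percentage points higher from compound 1 to compound 4 (within the scatter), so neither exchange moves the number beyond the scatter. No data are available that would explain these results.

From the compounds shown here alone, the furan-2-yl to thiophen-3-yl exchange changes both the hetero atom and the name's ring position, so the effect of each alone remains open, and thiophen-2-yl on the same carbon would separate the two. Going by these compounds, it also remains open whether a phenyl ring at this carbon, or an amine or a longer chain on the carbonyl carbon, would give a number beyond the scatter from these compounds.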